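A few compounds are considered here, and "the series" means these few. Any claim that something is new, unique, unknown or untested is made for them only; others in the source may bear on it.

Measured compounds:
compound 1 `CC1CCN(c2c(S(=O)(=O)c3ccc(Cl)cc3)cnc3cc(Cl)ccc23)CC1` — 91%
compound 2 `CC1CCN(c2c(S(=O)(=O)c3ccc(Cl)c(Cl)c3)cnc3ccc(Cl)cc23)CC1` — 86%
compound 3 `COc1ccc2ncc(S(=O)(=O)c3ccc(Cl)c(Cl)c3)c(N3CCC(C)CC3)c2c1` — 87%

In an assay on isolated protein for displacement of a labelled ligand from metabotropic glutamate receptor 5 (Homo sapiens), with a stated time of 60 min, tested at 1 uM (a lower number here means less inhibition, a higher number more inhibition at the concentration tested (going by the name of the read-out)), compound 3 stands second highest of the three numbers, nearest to compound 2 with a step of a number 1 percentage points higher from compound 2 to compound 3 (within the scatter) and furthest from compound 1, which lies within the scatter of it too. All three measured numbers thus sit close together.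

Compound 4 `COc1cccc(S(=O)(=O)c2cnc3ccc(OC)cc3c2N2CCC(C)CC2)c1` is not yet measured. It differs from compound 3 by 3-methoxyphenyl in place of 3,4-dichlorophenyl on a sulfonyl sulfur. Among the measured compounds shown here, the only measured single-point step, from compound 2 to compound 3, concerns a methoxy in place of a chloro on the core and bears on a different place from this one. Compound 1 and compound 2 carry different groups on the sulfonyl sulfur, but they also differ elsewhere, so their two values show only that both are high and within the scatter of each other. For the measured compounds named here, no measured step reads on a 3-methoxyphenyl here; the change removes both chlorines of the 3,4-dichlorophenyl and is larger than any step measured. A decrease beyond the scatter is therefore expected, though with wide uncertainty: compound 4 is estimated at 68% in this assay, range 40% to 90%, an expected step of a number 19 percentage points lower from compound 3 to compound 4 (beyond the scatter).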

Compound 4, a percentage reported as inhibition, at one concentration (the size of the read-out at that concentration, not a potency): 0%
Compound 4: middle estimate off by 68 percentage points, on the high side, outside the stated range (below it).
By their numbers in this assay, from the lowest: compound 4; then compounds 2, 3 and 1 (each within the scatter of the next).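

In this assay, the group on the sulfonyl sulfur turns out to control the read-out: 3-methoxyphenyl in place of 3,4-dichlorophenyl gives a number 87 percentage points lower from compound 3 to compound 4 (beyond the scatter) and leaves no measurable inhibition at the concentration tested. The core change, with a number 1 percentage points higher from compound 2 to compound 3 (within the scatter) as its step, gave no hint of this sensitivity, and both groups here hold 8 heavy atoms and one six-membered aromatic ring, so the loss goes with exchanging two chlorines for one methoxy rather than with that count. Nothing available explains the loss.

The shown compounds do not separate losing the chlorines from gaining the methoxy on this core. A 3-chlorophenyl or an unsubstituted phenyl on the sulfonyl sulfur would divide those two contributions.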